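The source may hold more compounds than are shown below. What is called first, only, known or untested is meant among the compounds shown, and "the series" means these compounds.

Measured so far:
- compound 1, `COc1ccc(/C=C2/C(=O)N(c3ccc(Cl)cc3)N=C2C)c(OC)c1`, which in an assay for inhibition of Alpha amylase (Homo sapiens), with a stated time of 10 min (a higher number here means a weaker inhibitor, a lower number a stronger inhibitor), gives 2010 nM
- compound 2, `COc1ccc(/C=C2/C(=O)N(c3ccc(Cl)cc3)N=C2C)cc1OC`, which in this assay gives 2030 nM

In this assay compound 2 gives the higher of the two numbers, but the nearest value, that of compound 1, sits so close that the pair lies within the usual scatter of repeated measurements, so neither compound can be called the stronger inhibitor. The two share one core and differ only in where their two methoxy groups sit on the outer ring, and that rearrangement does not move the number beyond the scatter.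

Compound 3, `COc1ccc(/C=C2/C(=O)N(c3ccc(Cl)cc3)N=C2C)c(OC)c1OC`, has not yet been measured. Its change from compound 2 is methoxy in place of hydrogen on an aromatic carbon, so the ring that already carries two methoxy groups gains a third.

Among the compounds with values here, no step between measured compounds is available to learn from. Adding one more small group of the same kind to a ring that already carries two is expected to shift this assay only a little, with no clear direction; the expected step is a 1.1-fold lower number from compound 2 to compound 3 (0.05 log units; within the scatter). Compound 3 is therefore estimated at 1800 nM, within a range from 700 nM to 4500 nM.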

Compound 3, half-maximal inhibitory concentration: 2100 nM
Compound 3: middle estimate off by 1.2-fold (0.07 log units), on the low side; the range from low to high includes it.
By their numbers in this assay, from the lowest: compounds 1, 2 and 3 (each within the scatter of the next).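

Adding a third methoxy group to the ring produces no change that can be told from the scatter in this assay: the step ortho to a large group and ortho to a methoxy group is (a 1.0-fold higher number from compound 2 to compound 3 (0.01 log units; within the scatter)), and the step that places the added methoxy on a different ring carbon is (a 1.0-fold higher number from compound 1 to compound 3 (0.02 log units; within the scatter)). Within the data shown here, the earlier pair showed only that moving one methoxy group around the ring leaves the number within the scatter, whereas these steps show that the ring can also carry an extra methoxy group without a readable shift in either case. No measurement here offers an explanation for this flat result.

All three compounds carry only methoxy groups on this ring, so the flat result says nothing yet about a different kind of group at the same position, such as a hydroxy group, an amine or a carboxylic acid, or about a longer chain such as butoxy. It also leaves open whether removing methoxy groups altogether, or replacing the chlorine on the other ring with a different group, would move the number beyond the scatter.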